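The source may hold more compounds than are shown below. What is called first, only, known or untested is meant among the compounds shown, and "the series" means these compounds.

Compound 1 `COc1cc(NC(C)CCCNC(=O)NNC(=O)Nc2ccc(F)cc2)c2ncccc2c1`: 118000 nM
Compound 2 `COc1cc(NC(C)CCCNC(=O)NNC(=O)Nc2cccc(F)c2)c2ncccc2c1`: 98000 nM

In a functional assay on CCRF-CEM cells (Homo sapiens) for inhibition, read by MTT assay, with a stated time of 72 h (on this read-out lower numbers stand for stronger inhibition and higher numbers for weaker inhibition), compound 2 gives 98000 nM, within the scatter of compound 1. Compound 3 `COc1cc(NC(C)CCCNC(=O)NNC(=O)Nc2cccc(C(F)(F)F)c2)c2ncccc2c1` differs from compound 2 by trifluoromethyl in place of fluoro on an aromatic carbon, with trifluoromethyl in place of fluoro on an aromatic carbon, meta to a large group. For the measured compounds named here, the only measured step, a 1.2-fold lower number from compound 1 to compound 2 (0.08 log units; within the scatter), replaces 4-fluorophenyl with 3-fluorophenyl and offers only indirect guidance, since no measured compound carries trifluoromethyl. A modest move to a lower number in this assay is expected, namely a 1.5-fold lower number from compound 2 to compound 3 (0.18 log units; within the scatter). The estimate for compound 3 is 65000 nM, with an expected range of 25000 nM to 130000 nM.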

Compound 3, half-maximal inhibitory concentration: 6900 nM
Estimate against measurement, compound 3: 9.4-fold (0.97 log units) above, outside the stated range (below it).
By their numbers in this assay, from the lowest: compound 3; then compounds 2 and 1 (each within the scatter of the next).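

In this assay the aromatic carbon meta to a large group proves sensitive to its substituent: trifluoromethyl in place of fluoro gives a 14-fold lower number from compound 2 to compound 3 (1.15 log units; beyond the scatter) and so separates from the earlier pair, which stayed within the scatter. Against the 4-fluorophenyl compound, 3-(trifluoromethyl)phenyl gives a 17-fold lower number from compound 1 to compound 3 (1.23 log units; beyond the scatter) and this step is of similar size. No evidence on hand accounts for the step.

Open, going by these compounds, is whether a nitrile or an amine on the same aromatic carbon would follow trifluoromethyl or fluoro. Also open, on these data alone, is how 4-(trifluoromethyl)phenyl would compare with 3-(trifluoromethyl)phenyl.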